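Swapping 3-methoxyphenyl for 4-methoxyphenyl on a shared core

This account rests on a few compounds, and the source may have more. Where it says the series, first, only, none or still open, it means among the compounds named here.

Compound 1 `COc1cccc(N2C(=O)COc3ccc(-c4cnc(Cl)c(NS(=O)(=O)c5ccc(F)cc5)c4)cc32)c1` gives > 40000 nM as a limit
Compound 2 `O=C1COc2ccc(-c3cccc(NS(=O)(=O)c4ccc(F)cc4)c3)cc2N1` gives > 40000 nM as a limit
Compound 3 `COc1ccc(N2C(=O)COc3ccc(-c4ccc(O)cc4)cc32)cc1` gives 16400 nM as a number

These values come from a functional assay on HeLa cells (Homo sapiens) for antiproliferative activity, read by MTT assay, with a stated time of 72 h (a lower number here means a stronger inhibitor, a higher number a weaker inhibitor), and only compound 3 has a number. Compound 1 reports only a limit (> 40000 nM) and has no number. Compound 4 `COc1ccc(N2C(=O)COc3ccc(-c4cnc(Cl)c(NS(=O)(=O)c5ccc(F)cc5)c4)cc32)cc1` has the same atoms, joined differently 4-methoxyphenyl in place of 3-methoxyphenyl on an amide-type nitrogen in a ring with 4-methoxyphenyl in place of 3-methoxyphenyl on an amide-type nitrogen in a ring.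

Among the measured compounds shown here, no measured step shows the effect of this change. Compound 3 also carries 4-methoxyphenyl and gives a number (16400 nM), so a small move toward stronger inhibition is expected in this assay or none beyond the scatter. The expected step of an at least 1.4-fold lower number from compound 1 to compound 4 (0.15 log units; that floor lies within the scatter) is modest. Compound 4 is estimated at 28000 nM (expected range 6000 nM to 40000 nM) and may again report only a limit.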

Compound 4, half-maximal inhibitory concentration: 8320 nM
Estimate against measurement, compound 4: 3.4-fold (0.53 log units) above, and the stated range covers the measured number.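

In this assay, 4-methoxyphenyl in place of 3-methoxyphenyl on the amide-type nitrogen in a ring gives an at least 4.8-fold lower number from compound 1 to compound 4 (0.68 log units; beyond the scatter). Among the compounds shown here, this is the only measured step at this position, and it shows that the same atoms, joined differently, are enough to bring the shared core from a limit to a number. Compound 1 reports only a limit, so the full size of the step cannot be read: the limit of > 40000 nM in this assay, at which 2 of the 4 values shown sit.

From the compounds shown here alone, whether 2-methoxyphenyl, 4-ethoxyphenyl or 4-aminophenyl at this position would lower the number further remains open. So does whether this swap acts the same way on another core.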